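The source may hold more compounds than are shown below. What is called first, only, known or untested is meant among the compounds shown, and "the series" means these compounds.

Compound 1 `O=C(c1ccc(OCCCN2CC[C@H](NS(=O)(=O)c3ccc(Br)cc3)C2)cc1)C1CC1`: 290 nM
Compound 2 `O=C(c1ccc(OCCCN2CC[C@H](NS(=O)(=O)c3ccc(F)cc3)C2)cc1)C1CC1`: 500 nM

In an assay on isolated protein for binding affinity to histamine H2 receptor (Homo sapiens) (on this read-out lower numbers stand for stronger inhibition and higher numbers for weaker inhibition), compound 2 gives 500 nM, the highest of the two numbers shown; its nearest neighbour is compound 1, and the only measured step, a 1.7-fold higher number from compound 1 to compound 2 (0.24 log units; within the scatter), lies within the scatter. Compound 3 `O=C(c1ccc(OCCCN2CC[C@H](NS(=O)(=O)c3ccc(Cl)cc3)C2)cc1)C1CC1` differs from compound 2 by chloro in place of fluoro on an aromatic carbon. Within the data shown here, the one step that bears on this change is a 1.7-fold higher number from compound 1 to compound 2 (0.24 log units; within the scatter), an exchange at the same aromatic carbon that stayed within the scatter, so no shift beyond the scatter is expected here either. Compound 3 is therefore estimated at 370 nM, with a range from 160 nM to 850 nM, which means an expected step of a 1.4-fold lower number from compound 2 to compound 3 (0.13 log units; within the scatter).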

Compound 3, inhibition constant: 290 nM
The estimate for compound 3 lay 1.3-fold (0.11 log units) above the measured number; the range from low to high includes it.
By their numbers in this assay, from the lowest: compounds 1, 3 and 2 (each within the scatter of the next).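

In this assay, chloro in place of fluoro on this aromatic carbon gives a 1.7-fold lower number from compound 2 to compound 3 (0.24 log units; within the scatter), while chloro in place of bromo gives no change at the digits printed from compound 1 to compound 3 (within the scatter). The three halogens at this carbon, para to a large group, thus all lie within the scatter of one another, and no order among them can be read. Nothing available explains this result. Going by these compounds, it remains open whether a methoxy, a nitrile or an amine at this carbon would move the number beyond the scatter.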